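Series notes: sulfonyl substituent change from compound 3 to compound 4

The compounds below may be only part of what the source reports. "The series", "measured", "known", "first", "only" and "open" are said of these compounds alone.

Measured so far:
- compound 1, `COC(=O)c1cc(=O)c2c(OC)cc(OC)cc2n1C`: in a functional assay on SUP-B15 cells (Homo sapiens) for antiproliferative activity, with a stated time of 72 h (a lower number here means that less compound is needed, a higher number that more compound is needed for the effect), compound 1 gives > 37900 nM; this is a limit of the assay, not a number.
- compound 2, `COC(=O)c1cc(=O)c2cc(N)ccc2[nH]1`: in this assay compound 2 gives > 67200 nM; this is a limit.
- compound 3, `COc1ccc(-c2cc(=O)c3c(OC)cc(OC)cc3n2S(=O)(=O)c2ccc(C)c([N+](=O)[O-])c2)cc1`: in this assay compound 3 gives > 51700 nM; this is a limit.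

Compound 3 therefore stands only at the limit of > 51700 nM in this assay, at which 1 of the 3 values shown sits, with no number behind it. For the measured compounds named here, the other two entries also sit at limits, the limit of > 37900 nM in this assay, at which 1 of the 3 values shown sits, and (the limit of > 67200 nM in this assay, at which 1 of the 3 values shown sits), so nothing in the set ranks the three compounds against one another, and no pair differing in a single place has been measured, so no step size is known from the data.

Compound 4, `COc1ccc(-c2cc(=O)c3c(OC)cc(OC)cc3n2S(=O)(=O)Cc2ccccc2)cc1`, is the next candidate. Relative to compound 3 the change is benzyl in place of 4-methyl-3-nitrophenyl on a sulfonyl sulfur. Going by the values given here, with compound 3 at a limit in this assay, no measured step supports any direction; the expectation is that compound 4 stays near the same limit, with no step beyond the scatter. Compound 4 is estimated at 50000 nM in this assay, within 15000 nM to 150000 nM. The estimated step of an at least 1.0-fold lower number from compound 3 to compound 4 (0.01 log units; that floor lies within the scatter) is expected to be small.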

Compound 4, half-maximal effective concentration: > 34400 nM
Compound 4 was reported as a limit; the forecaster's own chance of this, stated with the estimate: 75%; the middle value lies beyond the limit too.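

Compound 3 and compound 4 both stand at limits, so the step between them, benzyl in place of 4-methyl-3-nitrophenyl on a sulfonyl sulfur, cannot be read in this assay from these results. The compounds shown leave open whether any change to the sulfonyl substituent gives a measurable value in this assay at all.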